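Adding Fluoro to the Bromophenyl Compound: Expected Outcome

The compounds below may be only part of what the source reports. "The series", "measured", "known", "first", "only" and "open" are said of these compounds alone.

Three compounds share one core and differ only in the aryl group on the aromatic nitrogen. Compound 1 `CCNC(=O)c1cc(Oc2ccc(NC(=O)c3cc4cccnc4n(-c4ccccc4F)c3=O)cc2)ccn1` gives 490 nM in a functional assay on A549 cells (Homo sapiens) for antiproliferative activity, read by MTT assay, with a stated time of 72 h; a higher number here means a weaker inhibitor, a lower number a stronger inhibitor. Compound 2 `CCNC(=O)c1cc(Oc2ccc(NC(=O)c3cc4cccnc4n(-c4ccc(Cl)cc4)c3=O)cc2)ccn1` gives 250 nM in this assay, and compound 3 `CCNC(=O)c1cc(Oc2ccc(NC(=O)c3cc4cccnc4n(-c4ccc(Br)cc4)c3=O)cc2)ccn1` gives 910 nM in this assay. Compound 3 has the highest number of the three: the nearest step is a 1.9-fold higher number from compound 1 to compound 3 (0.27 log units; within the scatter), within the scatter, and the furthest is a 3.6-fold higher number from compound 2 to compound 3 (0.56 log units; beyond the scatter), beyond it. The remaining step, a 2.0-fold lower number from compound 1 to compound 2 (0.29 log units; within the scatter), is also within the scatter.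

Compound 4 `CCNC(=O)c1cc(Oc2ccc(NC(=O)c3cc4cccnc4n(-c4ccc(Br)cc4F)c3=O)cc2)ccn1` differs from compound 3 by fluoro in place of hydrogen on an aromatic carbon, ortho to a large group and meta to the bromo group. Going by the values given here, no measured step adds a fluoro to an otherwise unchanged aryl group: the two steps from compound 1 replace the whole 2-fluorophenyl, and the step from compound 2 to compound 3 exchanges one halogen for another. These steps were small to modest and give no direction for a single added fluoro. For compound 4 the step of a 1.1-fold lower number from compound 3 to compound 4 (0.06 log units; within the scatter) is expected to remain within the scatter. The estimate for compound 4 in this assay is 800 nM, with a range from 300 nM to 2500 nM.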

Compound 4, half-maximal inhibitory concentration: 1820 nM
The estimate for compound 4 lay 2.3-fold (0.36 log units) below the measured number, and the stated range covers the measured number.
By their numbers in this assay, from the lowest: compounds 2, 1, 3 and 4 (each within the scatter of the next, the first and the last beyond it).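

Notes on the series: In this assay, the step of a 2.0-fold higher number from compound 3 to compound 4 (0.30 log units; within the scatter) is the first direct reading of a single fluoro added to an otherwise unchanged aryl group, ortho to a large group and meta to a bromo group, and on the 4-bromophenyl this change cannot be told apart from the scatter. Going by these compounds alone, the 4-bromo-2-fluorophenyl group does, however, give two steps beyond the scatter: a 3.7-fold higher number from compound 1 to compound 4 (0.57 log units; beyond the scatter), the first reading of bromo in place of hydrogen with the fluoro held, and a 7.3-fold higher number from compound 2 to compound 4 (0.86 log units; beyond the scatter), which sets this group against the 4-chlorophenyl. Nothing available explains these steps.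

Whether the added fluoro would read the same on the 4-chlorophenyl of compound 2 remains open, as a 4-chloro-2-fluorophenyl group is not among the compounds shown. Also open, from the compounds shown here alone, is how an unsubstituted phenyl on the aromatic nitrogen, or a methoxy group or an amine in place of the bromo, would stand in this assay series.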